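The source may report more compounds than this note shows. Statements on the series, on what has been measured and on what is new or still open speak of the compounds shown alone.

Measured compounds in an assay on HEK293 cells for inhibition of Voltage-dependent T-type calcium channel subunit alpha-1G (Homo sapiens), read by fluorescence, tested at 10 uM; on this read-out higher numbers stand for more inhibition at the one concentration tested (going by the name of the read-out) and lower numbers for less inhibition:
Compound 1, `CCCc1nc(-c2ccccc2)c(CNCCN2CCN(c3ccccc3OC)CC2)o1`: 39.7%
Compound 2, `CCCc1nc(-c2ccccc2)c(CNCCCN2CCN(c3ccc(F)cc3)CC2)o1`: 62.5%
Compound 3, `CCCc1nc(-c2ccccc2)c(CNCCCN2CCN(c3ccccc3)CC2)o1`: 43.7%

Compound 1 gives the lowest of the three numbers; compound 3 stands within the scatter of it, while compound 2 stands beyond the scatter above it. Compound 4, `CCCc1nc(-c2ccccc2)c(CNCCN2CCN(c3cccc(F)c3)CC2)o1`, differs from compound 1 by 3-fluorophenyl in place of 2-methoxyphenyl on an amine nitrogen in a ring. Within the data shown here, only one measured step bears on this change: a number 18.8 percentage points lower from compound 2 to compound 3 (beyond the scatter), so the fluoro-bearing compound 2 reads higher than its hydrogen counterpart. Among the measured compounds shown here, that step was measured on compounds whose chain differs from that of compound 1, and no measured pair removes a methoxy group, so the expectation is loose. For compound 4 a modest rise is expected, a number 10.3 percentage points higher from compound 1 to compound 4 (beyond the scatter), in this assay. Compound 4 is estimated at 50%, with a range from 33% to 67%.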

Compound 4, a percentage reported as inhibition, at one concentration (the size of the read-out at that concentration, not a potency): 62.3%
Estimate against measurement, compound 4: 12.3 percentage points below; measured number inside the range.
By their numbers in this assay, from the lowest: compounds 1 and 3 (each within the scatter of the next); then compounds 4 and 2 (each within the scatter of the next).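

In this assay, the group on the amine nitrogen in the ring also matters on the chain of compound 1, where the change gives a number 22.6 percentage points higher from compound 1 to compound 4 (beyond the scatter). Among these compounds, the only earlier step at this position was on a different chain and involved only a fluoro group and hydrogen, whereas this one replaces 2-methoxyphenyl with 3-fluorophenyl. No measured evidence here explains the rise.

The compounds shown do not separate the loss of the methoxy group from the gain of fluoro or the shift in its place. A 3-methoxyphenyl or 2-fluorophenyl group on this chain would address that question.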